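Swapping Chloro for Fluoro Across Two Cores

The source may hold more compounds than are shown below. What is called first, only, known or untested is meant among the compounds shown, and "the series" means these compounds.

Compound 1 `CCc1nc(N)nc(N)c1-c1ccc2[nH]c(-c3ccc(Cl)cc3)[n+]([O-])c2c1` and compound 2 `CCc1nc(N)nc(N)c1-c1ccc2[nH]c(-c3ccc(F)cc3)[n+]([O-])c2c1` share one core, while compound 3 `Nc1ncc(-c2ccc(NCc3ccc(Cl)cc3)c([N+](=O)[O-])c2)cn1` and the as yet unmeasured compound 4 `Nc1ncc(-c2ccc(NCc3ccc(F)cc3)c([N+](=O)[O-])c2)cn1` share another; the difference between the two cores is not broken down here.

In a functional assay on HT-29 cells (Homo sapiens) for inhibition (on this read-out lower numbers stand for stronger inhibition of growth and higher numbers for weaker inhibition of growth), compound 1 reaches only a limit of the assay, > 50000 nM. In this assay compound 2 gives 46000 nM, and compound 3 gives 17000 nM, the lowest number among the measured pair. The change from compound 1 to compound 2, (fluoro in place of chloro on an aromatic carbon), brought an at least 1.0-fold lower number from compound 1 to compound 2 (0.03 log units; that floor lies within the scatter); because compound 1 sits at the limit of > 50000 nM in this assay, at which 1 of the 3 values shown sits, the true size of that step cannot be read. Compound 4 carries the same change, (fluoro in place of chloro on an aromatic carbon), on the other core.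

Among the compounds with values here, with the one measured step of this kind hidden by a limit, there is no basis for expecting more than a small shift, and the estimate for compound 4 is therefore a step of a 1.2-fold higher number from compound 3 to compound 4 (0.07 log units; within the scatter) in this assay. Compound 4 is thus expected to give about 20000 nM in this assay, most likely between 8000 nM and 50000 nM.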

Compound 4, concentration for 50% growth inhibition: 41000 nM
The estimate for compound 4 lay 2.1-fold (0.31 log units) below the measured number, within the range that was stated.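

On the core carrying the 4-chlorobenzyl group, fluoro in place of chloro gave a 2.4-fold higher number from compound 3 to compound 4 (0.38 log units; beyond the scatter) in this assay, so on this core the fluoro compound inhibited growth more weakly, by a modest but readable margin. Compound 1 gives only a limit of the assay and not a number, so the step on its core cannot be read: the limit of > 50000 nM in this assay, at which 1 of the 4 values shown sits. The series therefore offers one readable step and one open one, which shows the effect of the change on a single core but does not show that its size or direction carries over to the other: the same change on two cores in this assay, an at least 1.0-fold lower number (0.03 log units; that floor lies within the scatter) from compound 1 to compound 2 and a 2.4-fold higher number (0.38 log units; beyond the scatter) from compound 3 to compound 4; the limit leaves it open whether they differ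

The compounds shown leave open how a bromo or a methyl group in the same place would compare with chloro and fluoro on either core. They also leave open whether the step seen on the core of compound 4 would persist if an amine took the place of the nitro group.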